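Chloro for methyl across two cores of a pyridylamine series

A few compounds are considered here, and "the series" means these few. Any claim that something is new, unique, unknown or untested is made for them only; others in the source may bear on it.

Compound 1 `COc1ccc(Cl)c2ccc(Nc3cc(C)ccn3)nc12` and compound 2 `COc1ccc(Cl)c2ccc(Nc3cc(Cl)ccn3)nc12` share one core and differ by chloro in place of methyl on an aromatic carbon. In a functional assay on PC-3 cells (Homo sapiens) for antiproliferative activity, read by MTT assay, with a stated time of 96 h (on this read-out higher numbers stand for weaker inhibition of growth and lower numbers for stronger inhibition of growth), compound 1 gives > 30000 nM, a limit of the assay rather than a number. Compound 2 gives > 30000 nM, again a limit. The step that the two limits leave unreadable from compound 1 to compound 2 is thus of unknown size, since the limit of > 30000 nM in this assay, at which 2 of the 3 values shown sit, caps both values. Compound 3 `Cc1ccnc(Nc2ccc3cccc(O)c3n2)c1` has another core; the difference between the two cores is not broken down here. In this assay, within the data shown here, compound 3 gives 5840 nM, the only number so far. Compound 4 `Oc1cccc2ccc(Nc3cc(Cl)ccn3)nc12` is not yet measured and differs from compound 3 by chloro in place of methyl on an aromatic carbon, the same change as from compound 1 to compound 2. The measured step gives no size to lean on, so only a small expected step of a 1.1-fold higher number from compound 3 to compound 4 (0.05 log units; within the scatter) is assumed, resting on compound 3 at 5840 nM. Compound 4 is estimated at 6500 nM, expected between 2500 nM and 17000 nM.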

Compound 4, concentration for 50% growth inhibition: 2810 nM
For compound 4 the middle estimate is 2.3-fold (0.36 log units) above the measured one; the range from low to high includes it.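

In this assay, chloro in place of methyl on the core of compound 3 gives a 2.1-fold lower number from compound 3 to compound 4 (0.32 log units; beyond the scatter), a modest gain in inhibition of growth on this core. The step on the core of compound 1 cannot be read, since both of its compounds stand at a limit of the assay and not at a number: the limit of > 30000 nM in this assay, at which 2 of the 4 values shown sit. Whether the change carries from one core to the other is therefore not shown, as only one readable step exists.

Still open, from the compounds shown here alone, is whether an amine or a carboxylic acid on the same aromatic carbon, opposite the ring nitrogen, would shift the number further than chloro. Also open, going by these compounds, is how much of the difference between the two cores matters for growth inhibition.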